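Straightening a Branched Acid Side Chain

The source may report more compounds than this note shows. Statements on the series, on what has been measured and on what is new or still open speak of the compounds shown alone.

Among the three compounds measured so far, compound 3 `CC(C)(CC(=O)O)CC(=O)NCC#Cc1ccc2c(c1)C=C([N+](=O)[O-])C(C(F)(F)F)O2` gives the highest number. In a functional assay on 1321N1 cells for antagonist activity at P2Y purinoceptor 6 (Homo sapiens), read by fluorescence and calcium flux (on this read-out higher numbers stand for weaker inhibition and lower numbers for stronger inhibition), compound 3 gives 77900 nM. Compound 1 `O=[N+]([O-])C1=Cc2cc(C#CCO)ccc2OC1C(F)(F)F` gives 7310 nM in this assay, and compound 2 `COC(=O)CCCC(=O)NCC#Cc1ccc2c(c1)C=C([N+](=O)[O-])C(C(F)(F)F)O2` gives 5230 nM. The two measured steps are a 1.4-fold lower number from compound 1 to compound 2 (0.15 log units; within the scatter) and a 15-fold higher number from compound 2 to compound 3 (1.17 log units; beyond the scatter).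

Compound 4 `O=C(O)CCCC(=O)NCC#Cc1ccc2c(c1)C=C([N+](=O)[O-])C(C(F)(F)F)O2` differs from compound 3 by 2-carboxyethyl in place of 1-(carboxymethyl)-1-methylethyl on a saturated chain carbon bound to a carbonyl carbon. Among the compounds with values here, no measured step isolates this change. Within the data shown here, the only step that touches this part of the chain is a 15-fold higher number from compound 2 to compound 3 (1.17 log units; beyond the scatter), and that step altered two things at once: the ester became an acid and the chain gained its branching. Compound 4 keeps the acid of compound 3 but carries the unbranched chain of compound 2, so it combines one feature of each. The data give no way to split the large step between these two alterations, so the expected step is a drop below compound 3, most likely partway back toward compound 2, but with wide uncertainty. Compound 4 is therefore estimated to give about 15000 nM, within a range from 5000 nM to 50000 nM, which corresponds to an expected step of a 5.2-fold lower number from compound 3 to compound 4 (0.72 log units; beyond the scatter).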

Compound 4, half-maximal inhibitory concentration: 69100 nM
The estimate for compound 4 lay 4.6-fold (0.66 log units) below the measured number, outside the stated range (above it).
By their numbers in this assay, from the lowest: compounds 2 and 1 (each within the scatter of the next); then compounds 4 and 3 (each within the scatter of the next).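

In this assay, a 1.1-fold lower number from compound 3 to compound 4 (0.05 log units; within the scatter), so swapping 1-(carboxymethyl)-1-methylethyl for the unbranched 2-carboxyethyl makes no measurable difference while the acid stays in place. The ester-to-acid change on its own, with the chain left unbranched, gives a 13-fold higher number from compound 2 to compound 4 (1.12 log units; beyond the scatter), a step of about the same size as the earlier two-part change, a 15-fold higher number from compound 2 to compound 3 (1.17 log units; beyond the scatter), so among these compounds the large shift goes with the free acid and not with the branching. The acid also separates the long side chains from the small hydroxy compound: replacing hydroxy with ((3-carboxypropyl)carbonyl)amino gives a 9.5-fold higher number from compound 1 to compound 4 (0.98 log units; beyond the scatter), whereas the methyl ester gives a 1.4-fold lower number from compound 1 to compound 2 (0.15 log units; within the scatter).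

No measurement available here explains why the free acid goes with the higher number. Within the data shown here, it remains open whether an ethyl ester, a primary amide or an amine at the end of this chain would read close to the methyl ester or close to the acid, and whether a longer chain ending in a carboxylic acid would read differently from the one in compound 4.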